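The source may hold more compounds than are shown below. What is called first, only, known or untested is meant among the compounds shown, and "the series" means these compounds.

Compound 1 `O=C(NCc1cn(Cc2ccc(C(F)(F)F)cc2)nn1)c1cn(-c2ccccc2)nc1-c1ccccc1`: 1600 nM
Compound 2 `COc1ccc(Cn2cc(CNC(=O)c3cn(-c4ccccc4)nc3-c3ccccc3)nn2)cc1`: 6900 nM
Compound 3 `COc1ccc(-c2nn(-c3ccccc3)cc2C(=O)NCc2cn(Cc3ccc(C(F)(F)F)cc3)nn2)cc1`: 6200 nM

All three were tested in a functional assay on HeLa cells (Homo sapiens) for antiproliferative activity, read by sulforhodamine B assay, with a stated time of 48 h; a higher number here means a weaker inhibitor of growth, a lower number a stronger inhibitor of growth. Compound 1 gives 1600 nM, the lowest number of the three. Compound 2 gives 6900 nM and compound 3 gives 6200 nM; these two values lie within the scatter of each other, so nothing separates them.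

From compound 1 to compound 2 the change is methoxy in place of trifluoromethyl on an aromatic carbon, and the result is a 4.3-fold higher number from compound 1 to compound 2 (0.63 log units; beyond the scatter). Compound 3 differs from compound 1 in its core by methoxy in place of hydrogen on an aromatic carbon, with the result a 3.9-fold higher number from compound 1 to compound 3 (0.59 log units; beyond the scatter).

Compound 4 `COc1ccc(Cn2cc(CNC(=O)c3cn(-c4ccccc4)nc3-c3ccc(OC)cc3)nn2)cc1` has not yet been measured. It differs from compound 3 by methoxy in place of trifluoromethyl on an aromatic carbon, which is the same change as that from compound 1 to compound 2, made here on the core of compound 3, at the same place on the ring. Among the compounds with values here, the change is expected to cost about as much again, an estimated 3.5-fold higher number from compound 3 to compound 4 (0.55 log units; beyond the scatter), because the one earlier instance of it gave a 4.3-fold higher number from compound 1 to compound 2 (0.63 log units; beyond the scatter). Compound 4 is therefore expected to give roughly 22000 nM in this assay, most likely between 9000 nM and 55000 nM.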

Compound 4, concentration for 50% growth inhibition: 450 nM
Compound 4: middle estimate off by 49-fold (1.69 log units), on the high side; the whole stated range lies above it.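

Methoxy in place of trifluoromethyl on an aromatic carbon gives a 14-fold lower number from compound 3 to compound 4 (1.14 log units; beyond the scatter) in this assay, so this step runs opposite in direction to its earlier instance: the same change on two cores in this assay, a 4.3-fold higher number (0.63 log units; beyond the scatter) from compound 1 to compound 2 and a 14-fold lower number (1.14 log units; beyond the scatter) from compound 3 to compound 4, 59-fold (1.77 log units) apart, beyond the scatter of two such steps
Methoxy in place of hydrogen on an aromatic carbon likewise gives a 15-fold lower number from compound 2 to compound 4 (1.19 log units; beyond the scatter), and this step is reversed as well: the same change on two cores in this assay, a 3.9-fold higher number (0.59 log units; beyond the scatter) from compound 1 to compound 3 and a 15-fold lower number (1.19 log units; beyond the scatter) from compound 2 to compound 4, 59-fold (1.77 log units) apart, beyond the scatter of two such steps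
Across these four compounds, neither change can be carried from one core to another, even in direction, which shows that the outcome of each depends on what stands at the other place; it does not show why the two places are coupled, or whether the same holds on any other core.

The compounds shown carry only trifluoromethyl or methoxy at one of the two places and only hydrogen or methoxy at the other. From the compounds shown here alone, whether a chlorine, a hydroxyl or an amine at either place would follow the same reversal remains open, as does whether it would appear in any other cell line.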